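The compounds below may be only part of what the source reports. "The series", "measured", "known", "first", "only" and "open" are said of these compounds alone.

The series rests on a shared core whose members differ only in the group attached to the nitrogen of the proline-like ring. Compound 1, `C=C[C@@H]1C[C@]1(NC(=O)[C@@H]1C[C@@H](Oc2cc(-c3ccccc3)nc3cc(OC)ccc23)CN1C(=O)[C@@H](NC(=O)OC(C)(C)C)C(C)(C)C)C(=O)NS(=O)(=O)C1CC1`, is the best characterised of them. Going by the values given here, in an ADME assay on the whole organism (plasma, Rattus norvegicus, strain Sprague-Dawley) for pharmacokinetics, read by LC-MS, with a stated time of 4 h, at a dose of 15 mg/kg by the intraduodenal route (a lower number here means less compound in the circulation, a higher number more compound in the circulation at the dose given), compound 1 gives 61 ng.h/mL, the highest of the two numbers measured so far. Its nearest neighbour is compound 2, `C=C[C@@H]1C[C@]1(NC(=O)[C@@H]1C[C@@H](Oc2cc(-c3ccccc3)nc3cc(OC)ccc23)CN1C(=O)[C@H]([C@@H](C)CC)N(C)C(=O)NC(C)(C)C)C(=O)NS(=O)(=O)C1CC1`, which in this assay gives 16 ng.h/mL, a gap that lies beyond the usual scatter of the measurement.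

The next compound to be examined is compound 3, `C=C[C@@H]1C[C@]1(NC(=O)[C@@H]1C[C@@H](Oc2cc(-c3ccccc3)nc3cc(OC)ccc23)CN1C(=O)[C@@H](OC(=O)NC(C)(C)C)C(C)(C)C)C(=O)NS(=O)(=O)C1CC1`, which has the same atoms as compound 1 joined in a different way. The change is ((tert-butyl)carbamoyl)oxy in place of (tert-butoxycarbonyl)amino on a saturated chain carbon bound to a carbonyl carbon and a saturated chain carbon. Among the compounds with values here, no pair of compounds measured so far shows the effect of this change, so any expectation for compound 3 must lean on compound 1 alone. Because compound 1 gives 61 ng.h/mL in this assay, and the rearrangement is small, the step expected in this assay from compound 1 to compound 3 is a 1.4-fold lower number from compound 1 to compound 3 (0.13 log units; within the scatter), one that may fall within the scatter. Compound 3 is thus expected to give about 45 ng.h/mL, somewhere between 15 ng.h/mL and 130 ng.h/mL.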

Compound 3, area under the concentration-time curve: 82 ng.h/mL
Compound 3: the middle estimate sits 1.8-fold (0.26 log units) below what was measured; the range from low to high includes it.
By their numbers in this assay, from the lowest: compound 2; then compounds 1 and 3 (each within the scatter of the next).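

In this assay, placing ((tert-butyl)carbamoyl)oxy where (tert-butoxycarbonyl)amino stood on a saturated chain carbon bound to a carbonyl carbon and a saturated chain carbon gives a 1.3-fold higher number from compound 1 to compound 3 (0.13 log units; within the scatter) and so leaves the two compounds indistinguishable in this measurement. Going by these compounds alone, this is the first pair that differs in one place, and it shows that the same atoms can be joined differently here, with the counts of donors and acceptors unchanged, without a step that rises above the scatter. No supporting measurement accounts for this result.

The compounds shown test only this one rearrangement, so they cannot say whether the result would hold for a different group on this carbon, such as a simple amine, a carboxylic acid or a longer chain. They also leave open whether replacing the tert-butyl end of the ((tert-butyl)carbamoyl)oxy group with a cyclopentyl ring would move the reading in this assay beyond the scatter.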